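The source may report more compounds than this note shows. Statements on the series, on what has been measured and on what is new or still open speak of the compounds shown alone.

In a functional assay on NCI-H460 cells (Homo sapiens) for inhibition, read by MTT assay, with a stated time of 72 h (a higher number here means a weaker inhibitor, a lower number a stronger inhibitor), three related compounds have been measured. Compound 1 `Cc1nc(-c2ccc(F)cc2)c(C(=O)N2CCN(c3cc(Cl)cc(Cl)c3)CC2)o1` gives 243 nM, compound 2 `COc1cc(OC)cc(N2CCN(C(=O)c3oc(C)nc3-c3ccccc3F)CC2)c1` gives 42 nM, and compound 3 `COc1cc(OC)cc(N2CCN(C(=O)c3oc(C)nc3-c3ccc(F)cc3)CC2)c1` gives 68 nM. Compound 3 therefore lies within the scatter of compound 2 and is clearly stronger than compound 1. The unmeasured compound 4 `COc1cc(OC)cc(N2CCN(C(=O)c3oc(C)nc3-c3cccc(F)c3)CC2)c1` carries 3-fluorophenyl in place of 4-fluorophenyl on an aromatic carbon of the five-membered aromatic ring with 1 nitrogen and 1 oxygen (3-fluorophenyl in place of 4-fluorophenyl on an aromatic carbon). Within the data shown here, the closest precedent is the swap of 4-fluorophenyl in place of 2-fluorophenyl, a 1.6-fold higher number from compound 2 to compound 3 (0.21 log units; within the scatter), which stays within the scatter. The larger change, a 3.6-fold lower number from compound 1 to compound 3 (0.55 log units; beyond the scatter), comes from 3,5-dimethoxyphenyl in place of 3,5-dichlorophenyl, a group that compound 4 leaves untouched, so it says little about this swap. No step beyond the scatter is therefore expected in this assay, in either direction. The expected change is small, a 1.2-fold lower number from compound 3 to compound 4 (0.09 log units; within the scatter). Compound 4 is estimated at 55 nM, with an expected range from 25 nM to 120 nM.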

Compound 4, half-maximal inhibitory concentration: 67 nM
Compound 4: middle estimate off by 1.2-fold (0.09 log units), on the low side; the measured number falls inside the stated range.
By their numbers in this assay, from the lowest: compounds 2, 4 and 3 (each within the scatter of the next); then compound 1.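

In this assay, moving the fluorine to give 3-fluorophenyl on this aromatic carbon, next to the ring nitrogen, yields a 1.0-fold lower number from compound 3 to compound 4 (0.01 log units; within the scatter) and, against the other fluorinated isomer, a 1.6-fold higher number from compound 2 to compound 4 (0.20 log units; within the scatter) in the same series. With this third placement, the 2-fluorophenyl, 3-fluorophenyl and 4-fluorophenyl compounds all lie within the scatter of one another, so in this 3,5-dimethoxyphenyl series the place of the fluorine on the phenyl ring does not separate them in this assay. Nothing shown here accounts for this result.

The compounds shown leave open whether a phenyl without fluorine, or a 3-chlorophenyl, 3-methoxyphenyl or 3-aminophenyl group, would stay within the same range. They also leave open whether 3-fluorophenyl would behave the same way alongside the 3,5-dichlorophenyl group of compound 1.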